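The source may report more compounds than this note shows. Statements on the series, on what has been measured and on what is new or still open speak of the compounds shown alone.

In a functional assay on BXPC-3 cells (Homo sapiens) for inhibition, read by MTT assay, with a stated time of 72 h (a lower number here means a stronger inhibitor, a higher number a weaker inhibitor), compound 1 `COc1cc(NC(=O)c2ncccn2)c2ncccc2c1` gives > 10000 nM, which is a limit of the assay and not a number. Compound 2 `O=C(Nc1cc(OCCF)cc2cccnc12)c1cnccn1` gives 4330 nM. Compound 3 `CC(C)(C)OC(=O)NCCOc1cc(NC(=O)c2cnccn2)c2ncccc2c1` gives 9170 nM, the higher of the two actual numbers. For the measured compounds named here, the only measured step, a 2.1-fold higher number from compound 2 to compound 3 (0.33 log units; beyond the scatter), is modest and lies on the chain, not at the carbonyl. Compound 4 `CC(C)(C)OC(=O)NCCOc1cc(NC(=O)c2ncccn2)c2ncccc2c1` keeps that chain and changes one group: pyrimidin-2-yl in place of pyrazin-2-yl on a carbonyl carbon. Going by the values given here, no measured pair shows this swap. Compound 1 also carries pyrimidin-2-yl, and its > 10000 nM is a limit, so the expectation leans slightly upward. The expected change is no clear step beyond the scatter in this assay: a 1.1-fold higher number from compound 3 to compound 4 (0.04 log units; within the scatter). For compound 4 the estimate is 10000 nM, with an expected range of 4500 nM to 22000 nM.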

Compound 4, half-maximal inhibitory concentration: > 10000 nM
Compound 4: no number, only a limit; the forecaster's own chance of this, stated with the estimate: 50%; the middle value lies on the limit itself.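

In this assay, for the compounds shown here, the first measured pair for this swap gives an at least 1.0-fold higher number from compound 3 to compound 4 (0.03 log units; that floor lies within the scatter) when pyrimidin-2-yl replaces pyrazin-2-yl on a carbonyl carbon. That floor shows no change beyond the scatter, but it does not rule out a larger one. The value of compound 4 is a limit of the assay and not a number, and the step from compound 1 to compound 4 cannot be read, so the true size stays unknown: the limit of > 10000 nM in this assay, at which 2 of the 4 values shown sit.

As far as these compounds go, whether pyrimidin-2-yl would behave the same way with the fluoro chain of compound 2 stays open. So does whether a free amine in place of (tert-butoxycarbonyl)amino, or a longer chain, would lower the number.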